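Lengthening the acyl chain from compound 2 to compound 4

The compounds below may be only part of what the source reports. "The series", "measured", "known", "first", "only" and "open" are said of these compounds alone.

Measured in a functional assay on HepG2 cells (Homo sapiens) for cytotoxicity; a lower number here means that less compound is tolerated, a higher number that more compound is tolerated:
- compound 1 `CC(=O)Nc1nc(N)nc2c1ncn2[C@H]1CO[C@@H](CO)O1` gives > 100000 nM
- compound 2 `CCCCCCCC(=O)Nc1nc(N)nc2c1ncn2[C@H]1CO[C@@H](CO)O1` gives > 100000 nM
- compound 3 `CCCCCCCCCCCCCC(=O)Nc1nc(N)nc2c1ncn2[C@H]1CO[C@@H](CO)O1` gives 56000 nM

Compound 1 stands at a limit, > 100000 nM, not a number. As far as these compounds go, compound 2 stands at > 100000 nM, also a limit, so its true position is unknown. The change to compound 4 `CCCCCCCCCCCCCCCC(=O)Nc1nc(N)nc2c1ncn2[C@H]1CO[C@@H](CO)O1` is octyl in place of hydrogen on a saturated chain carbon, seven bonds along the chain from a carbonyl carbon. Within the data shown here, two measured steps bear on it. Among the measured compounds shown here, the first is a step that the two limits leave unreadable from compound 1 to compound 2. The closer one, with hexyl entering at the same place, is an at least 1.7-fold lower number from compound 2 to compound 3 (0.25 log units; that floor lies within the scatter). Octyl extends that change, so a lower number of similar or slightly larger size is expected, though a limit remains possible. The expected step is an at least 2.5-fold lower number from compound 2 to compound 4 (0.39 log units; beyond the scatter). The estimate for compound 4 is 40000 nM, with an expected range of 15000 nM to 100000 nM.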

Compound 4, half-maximal cytotoxic concentration: > 100000 nM
Compound 4: no number, only a limit; the forecaster's own chance of this, stated with the estimate: 25%; middle value at least 2.5-fold (0.39 log units) from the limit.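

In this assay compound 4 gives > 100000 nM, a limit and not a number. The ethyl added gives an at least 1.7-fold higher number from compound 3 to compound 4 (0.25 log units; that floor lies within the scatter), so the lower number seen with compound 3 does not continue with chain length. The steps between limits cannot be read, leaving little to compare: the limit of > 100000 nM in this assay, at which 3 of the 4 values shown sit.

Still open, as far as these compounds go, is whether compound 3 truly stands apart from compound 2 and compound 4. Also open, from the compounds shown here alone, is how an acyl chain ending in a carboxylic acid or an amine would read in this assay.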